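The source may report more compounds than this note shows. Statements on the series, on what has been measured and on what is new or still open speak of the compounds shown alone.

Among the measured compounds shown here, in an ADME assay for permeability, using PAMPA, with a stated time of 30 min, at pH 7.4 (a lower number here means that the compound crosses the layer more slowly, a higher number that the compound crosses the layer faster), three compounds have numbers so far. For the measured compounds named here, compound 1 `c1ccc(-c2ccc3c(NCCCNCc4ccco4)ccnc3c2)cc1` gives 237 10^-6 cm/s, and compound 2 `Fc1ccc(-c2ccc3c(NCCCNCc4ccco4)ccnc3c2)cc1` gives 237 10^-6 cm/s; the one step between them, no change at the digits printed from compound 1 to compound 2 (within the scatter), is the only measured step in the set. Compound 3 `COc1cccc(CNCCCNc2ccnc3cc(Cc4ccccc4)ccc23)c1O` gives 23 10^-6 cm/s, the lowest of the three numbers, and its gaps to compound 1 and to compound 2 both lie beyond the scatter. Compound 4 `COc1cccc(CNCCCNc2ccnc3cc(Oc4cccc(N(C)C)c4)ccc23)c1O` is not yet measured. It differs from compound 3 by 3-(dimethylamino)phenoxy in place of benzyl on an aromatic carbon. Going by the values given here, no measured step bears directly on this change: the single step seen, from compound 1 to compound 2, swaps a fluorine for a hydrogen, which is a different kind of change from the one here, and it showed no movement beyond the scatter. With nothing else to lean on, the expectation for compound 4 in this assay rests on the value of compound 3, 23 10^-6 cm/s, and allows for a modest shift in either direction. Compound 4 is therefore expected to give about 20 10^-6 cm/s, between 7 10^-6 cm/s and 60 10^-6 cm/s. The expected step is a 1.2-fold lower number from compound 3 to compound 4 (0.06 log units; within the scatter), which would stay within the scatter.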

Compound 4, apparent permeability: 317 10^-6 cm/s
For compound 4 the middle estimate is 16-fold (1.20 log units) below the measured one; measured number above the stated range.
By their numbers in this assay, from the lowest: compound 3; then compounds 1, 2 and 4 (each within the scatter of the next).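

In this assay, among the compounds shown here, this aromatic carbon, meta to a fused ring and para to a fused ring, proves sensitive to what it carries: 3-(dimethylamino)phenoxy in place of benzyl gives a 14-fold higher number from compound 3 to compound 4 (1.14 log units; beyond the scatter), the first step in the set beyond the scatter, whereas the fluoro for hydrogen swap gave no change at the digits printed from compound 1 to compound 2 (within the scatter). The change alters several things at once, since the entering group brings 10 heavy atoms and 2 hydrogen-bond acceptors where benzyl had 7 heavy atoms and 0 acceptors, so this single pair cannot separate the contributions of its parts. Nothing at hand accounts for the size of this rise.

Going by these compounds, what a plain phenoxy or a 3-methoxyphenoxy group would give at this carbon stays open. So does whether the dimethylamino group matters at all, or whether the same change would hold on the core of compound 1.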